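The compounds below may be only part of what the source reports. "The series", "measured", "known", "first", "only" and "open" are said of these compounds alone.

In an assay on isolated protein for inhibition of Aromatase (Homo sapiens), read by fluorescence and colorimetric assay, with a stated time of 30 min (a higher number here means a weaker inhibitor, a lower number a stronger inhibitor), compound 1 `N#Cc1ccc(C(c2ccc(C#N)cc2)n2cc(COc3ccccc3)nn2)cc1` gives 11000 nM, and compound 2 `N#Cc1ccc(Cn2cc(COc3ccccc3)nn2)cc1` gives 6090 nM. Among the compounds with values here, the only measured step, a 1.8-fold lower number from compound 1 to compound 2 (0.26 log units; within the scatter), lies within the scatter, so compound 2 holds the lowest of the two numbers without standing apart from compound 1. Compound 3 `N#Cc1ccc(Cn2cc(COc3ccc([N+](=O)[O-])cc3)nn2)cc1` differs from compound 2 by nitro in place of hydrogen on an aromatic carbon. Within the data shown here, no measured step bears on this change, since a 1.8-fold lower number from compound 1 to compound 2 (0.26 log units; within the scatter) concerns a different place on the shared core; the data give no ground for a step beyond the scatter. Compound 3 is therefore expected to show an estimated 6000 nM, between 2500 nM and 15000 nM, amounting to a 1.0-fold lower number from compound 2 to compound 3 (0.01 log units; within the scatter).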

Compound 3, half-maximal inhibitory concentration: 5620 nM
Compound 3: middle estimate off by 1.1-fold (0.03 log units), on the high side, within the range that was stated.
By their numbers in this assay, from the lowest: compounds 3, 2 and 1 (each within the scatter of the next).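

In this assay, nitro in place of hydrogen on an aromatic carbon, para to a large group, gives a 1.1-fold lower number from compound 2 to compound 3 (0.03 log units; within the scatter) and so stays within the scatter. Within the data shown here, this is the first measured step at this place on the six-membered aromatic ring, and it shows that these 3 heavy atoms can enter there without a step beyond the scatter. Nothing measured here explains this result. On these data alone, whether an amine or a carboxylic acid at this place would also stay within the scatter of compound 2 remains open. So does the effect of nitro elsewhere on that ring.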